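The source may report more compounds than this note shows. Statements on the series, on what has been measured and on what is new or still open speak of the compounds shown alone.

Of the compounds shown here, three sharing one core have been tested in a functional assay on LNCaP cells (Homo sapiens) for antiproliferative activity; on this read-out higher numbers stand for weaker inhibition and lower numbers for stronger inhibition. There compound 1 `Cn1ncc(Cl)c1-c1cc(C(=O)N[C@@H]2CN[C@H](CCCO)C[C@H]2c2ccc(Cl)c(Cl)c2)oc1Cl` gives 210 nM, compound 2 `Cn1ncc(Cl)c1-c1cc(C(=O)N[C@@H]2CN[C@H](CCN3CCCCC3)C[C@H]2c2ccc(Cl)c(Cl)c2)oc1Cl` gives 1780 nM, and compound 3 `C=CC[C@@H]1C[C@@H](c2ccc(Cl)c(Cl)c2)[C@H](NC(=O)c2cc(-c3c(Cl)cnn3C)c(Cl)o2)CN1` gives 160 nM. Compound 3 thus shares the low end of the set with compound 1, the two being separated only by a 1.3-fold lower number from compound 1 to compound 3 (0.12 log units; within the scatter).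

Compound 4 `Cn1ncc(Cl)c1-c1cc(C(=O)N[C@@H]2CN[C@H](CCN3CCCC3)C[C@H]2c2ccc(Cl)c(Cl)c2)oc1Cl` carries (pyrrolidin-1-yl)methyl in place of vinyl on a saturated chain carbon bound to a saturated ring carbon. The closest evidence is the large step between vinyl and (piperidin-1-yl)methyl at that same place in compound 2, an 11-fold lower number from compound 2 to compound 3 (1.05 log units; beyond the scatter). Read in reverse, it points towards a higher number. The modest step of an 8.5-fold higher number from compound 1 to compound 2 (0.93 log units; beyond the scatter) points the same way. A large rise in this assay, beyond the scatter, is therefore expected. The expected change is an 8.8-fold higher number from compound 3 to compound 4 (0.94 log units; beyond the scatter). Compound 4 is estimated at 1400 nM, with an expected range of 550 nM to 3500 nM.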

Compound 4, half-maximal inhibitory concentration: 1920 nM
Compound 4: middle estimate off by 1.4-fold (0.14 log units), on the low side; the range from low to high includes it.
By their numbers in this assay, from the lowest: compounds 3 and 1 (each within the scatter of the next); then compounds 2 and 4 (each within the scatter of the next).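

With pyrrolidin-1-yl in place of piperidin-1-yl, the number in this assay stays within the scatter (a 1.1-fold higher number from compound 2 to compound 4 (0.03 log units; within the scatter)), so these two rings cannot be told apart at this position. The large gap seen with the piperidine compound is now matched by a second ring amine, both against the allyl group of compound 3 (a 12-fold higher number from compound 3 to compound 4 (1.08 log units; beyond the scatter)) and against the 3-hydroxypropyl chain of compound 1 (a 9.1-fold higher number from compound 1 to compound 4 (0.96 log units; beyond the scatter)), so among these four compounds both ring amines sit high and neither compound 1 nor compound 3 does. Nothing at hand explains this split.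

From the compounds shown here alone, it remains open whether a morpholin-4-yl ring or an open-chain dimethylamino group in the same place would fall with compounds 2 and 4 or with compounds 1 and 3. A carboxylic acid or a longer chain carrying the pyrrolidine is equally unresolved.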